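The source may report more compounds than this note shows. Statements on the series, on what has been measured and on what is new or still open speak of the compounds shown alone.

Measured compounds in an assay for inhibition of Amine oxidase [flavin-containing] A (Homo sapiens); a lower number here means a stronger inhibitor, a higher number a weaker inhibitor:
Compound 1 `O=C1O[C@@H](Cn2ccnn2)CN1c1ccc(-c2ccc(CO)nc2)c(F)c1` gives 4800 nM.
Compound 2 `O=C(c1ccc(-c2ccc(N3C[C@H](Cn4ccnn4)OC3=O)cc2F)cn1)C1CNC1` gives 4500 nM.
Compound 3 `COCc1ccc(-c2ccc(N3C[C@H](Cn4ccnn4)OC3=O)cc2F)cn1` gives 1700 nM.

Compound 2 stands second highest of the three numbers; its nearest neighbour is compound 1, with a 1.1-fold lower number from compound 1 to compound 2 (0.03 log units; within the scatter), and its furthest is compound 3, with a 2.6-fold lower number from compound 2 to compound 3 (0.42 log units; beyond the scatter). Compound 4 `CC(C)(O)c1ccc(-c2ccc(N3C[C@H](Cn4ccnn4)OC3=O)cc2F)cn1` carries the change (1-hydroxy-1-methylethyl in place of (azetidin-3-yl)carbonyl on an aromatic carbon). Going by the values given here, two measured steps bear on it: the replacement of the (azetidin-3-yl)carbonyl by methoxymethyl gave a 2.6-fold lower number from compound 2 to compound 3 (0.42 log units; beyond the scatter), a modest step, while the swap between hydroxymethyl and (azetidin-3-yl)carbonyl gave a 1.1-fold lower number from compound 1 to compound 2 (0.03 log units; within the scatter), within the scatter. The 1-hydroxy-1-methylethyl group resembles the hydroxymethyl of compound 1, so a small step, if any, is expected in this assay, written as a 1.3-fold lower number from compound 2 to compound 4 (0.11 log units; within the scatter). Compound 4 is therefore estimated at 3500 nM, between 1500 nM and 8000 nM.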

Compound 4, inhibition constant: 6000 nM
Compound 4: the middle estimate sits 1.7-fold (0.23 log units) below what was measured; measured number inside the range.
By their numbers in this assay, from the lowest: compound 3; then compounds 2, 1 and 4 (each within the scatter of the next).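

In this assay the 1-hydroxy-1-methylethyl group on this aromatic carbon, next to the ring nitrogen, reads level with the larger (azetidin-3-yl)carbonyl (a 1.3-fold higher number from compound 2 to compound 4 (0.12 log units; within the scatter)) and with hydroxymethyl (a 1.3-fold higher number from compound 1 to compound 4 (0.10 log units; within the scatter)). Methoxymethyl alone stands apart from it (a 3.5-fold higher number from compound 3 to compound 4 (0.55 log units; beyond the scatter)), so at this position methyl on the oxygen and methyl groups on the saturated carbon do not read alike. Going by these compounds, whether an amine, a carboxylic acid or a longer ether chain here would move the number further stays open. Nothing given accounts for the separation of methoxymethyl from the other groups.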